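The source may report more compounds than this note shows. Statements on the series, on what has been measured and on what is new or still open speak of the compounds shown alone.

Compound 1 `O=C(COc1cccc2ccccc12)N/N=C/c1ccc(Cl)cc1`: 100 ug/mL
Compound 2 `C/C(=N\NC(=O)COc1cccc2ccccc12)c1ccc(C#N)cc1Br`: 20 ug/mL

Both numbers come from an ADME assay on HEL cells (Homo sapiens) for cytotoxicity; a lower number here means that less compound is tolerated, a higher number that more compound is tolerated. Compound 1 holds the higher of the two values; compound 2 sits lower, and that gap lies beyond the usual scatter. Compound 3 `O=C(COc1cccc2ccccc12)N/N=C/c1ccc(F)cc1` has not been measured yet. It differs from compound 1 in a single place: fluoro in place of chloro on an aromatic carbon. Going by the values given here, no measured pair shows this change, so no step can be read off; the expected step in this assay is small, as no change at the digits printed from compound 1 to compound 3 (within the scatter), and may not go beyond the scatter. For compound 3 the estimated value in this assay is 100 ug/mL, with a range from 50 ug/mL to 200 ug/mL.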

Compound 3, minimum cytotoxic concentration: 100 ug/mL
Estimate against measurement, compound 3: no gap at the digits printed; low and high end bracket the measured number.
By their numbers in this assay, from the lowest: compound 2; then compounds 1 and 3 (each within the scatter of the next).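

In this assay, going by these compounds alone, putting fluoro in place of chloro on this aromatic carbon gives no change at the digits printed from compound 1 to compound 3 (within the scatter), the first reading of a single change at this position. At this place, para to a large group, these two halogens therefore cannot be told apart by this read-out. Nothing available here explains why they read alike.

Both groups are single halogen atoms, so this step says little about larger or quite different groups. On these data alone, whether an amine, a carboxylic acid or a methoxy group on the same carbon would keep the number where it stands remains open.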